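Ethynyl for Formyl on a Spiro Core: an Expected Step

The compounds below may be only part of what the source reports. "The series", "measured", "known", "first", "only" and "open" are said of these compounds alone.

Measured compounds:
Compound 1, `C=C1CC[C@@H](C(C)C)[C@]12CC=C(C=O)CC2`: 165000 nM
Compound 2, `C=C1CCC[C@]2(C)CCC(C=O)=CC[C@@]12C`: 152000 nM
Compound 3, `C#CC1=CC[C@@]2(C)C(=C)CCC[C@]2(C)CC1`: 387000 nM

All three were tested in a functional assay on DU-145 cells (Homo sapiens) for cytotoxicity, read by MTT assay, with a stated time of 48 h; on this read-out higher numbers stand for weaker inhibition and lower numbers for stronger inhibition. Compound 1 and compound 2 give numbers within the scatter of each other; the difference between their two cores is not broken down here. Compound 3 differs from compound 2 by ethynyl in place of formyl on a double-bonded ring carbon, and this change gave a 2.5-fold higher number from compound 2 to compound 3 (0.41 log units; beyond the scatter).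

Compound 4, `C#CC1=CC[C@]2(CC1)C(=C)CC[C@H]2C(C)C`, differs from compound 1 by ethynyl in place of formyl on a double-bonded ring carbon. Here the change sits on a six-membered ring joined at one shared atom, whereas in compound 3 it sits on a seven-membered ring of a fused system, so it is the same kind of change rather than the same. Compound 4 is expected to show a 2.3-fold higher number from compound 1 to compound 4 (0.36 log units; beyond the scatter), resting on the step seen in compound 3 of a 2.5-fold higher number from compound 2 to compound 3 (0.41 log units; beyond the scatter). Compound 4 is thus estimated at 380000 nM, between 170000 nM and 900000 nM.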

Compound 4, half-maximal inhibitory concentration: 121000 nM
For compound 4 the middle estimate is 3.1-fold (0.50 log units) above the measured one; the measured number lies below the stated range.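

On the core of compound 1, ethynyl in place of formyl in this assay gave a 1.4-fold lower number from compound 1 to compound 4 (0.13 log units; within the scatter), so the weaker inhibition seen on the other core did not appear here. The two cores answered differently to this change: the same change on two cores in this assay, a 2.5-fold higher number (0.41 log units; beyond the scatter) from compound 2 to compound 3 and a 1.4-fold lower number (0.13 log units; within the scatter) from compound 1 to compound 4, 3.5-fold (0.54 log units) apart, beyond the scatter of two such steps. Going by these compounds alone, the step therefore cannot be carried from one core to the other as a fixed amount, but with only one pair per core, this does not show which feature of the cores sets the difference.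

The compounds shown leave open whether a nitrile or a carboxylic acid on the same double-bonded ring carbon would also differ from core to core. On these data alone, whether a longer chain ending in ethynyl would do so also stays open.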